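Bromo in place of ethynyl on the anilino ring

A few compounds are considered here, and "the series" means these few. Any claim that something is new, unique, unknown or untested is made for them only; others in the source may bear on it.

Compound 1 `C#Cc1cccc(Nc2ncnc3cc(NC(=O)c4ccc(C(=O)Nc5ccccc5N)cc4)ccc23)c1` and compound 2 `C#Cc1cccc(Nc2ncnc3ccc(OCc4ccc(C(=O)Nc5ccccc5N)cc4)cc23)c1` share the same core. In an assay on cells for inhibition of histone deacetylase 8 (Homo sapiens), read by fluorescence, with a stated time of 180 min (a higher number here means a weaker inhibitor, a lower number a stronger inhibitor), compound 1 returns only a limit, > 32000 nM. In this assay compound 2 likewise returns only a limit, > 32000 nM. Among the compounds with values here, both values sit at the limit of > 32000 nM in this assay, at which 2 of the 2 values shown sit, so no measured step exists. Compound 3 `Nc1ccccc1NC(=O)c1ccc(COc2ccc3ncnc(Nc4cccc(Br)c4)c3c2)cc1` follows from compound 2 by bromo in place of ethynyl on an aromatic carbon. Within the data shown here, with no measured step to lean on, the step in this assay is expected to be a step that the limit leaves unreadable from compound 2 to compound 3, none beyond the scatter. Compound 3 is estimated at 40000 nM, between 15000 nM and 120000 nM, most probably again only a limit.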

Compound 3, half-maximal inhibitory concentration: > 32000 nM
Compound 3: a limit, no number; the forecaster's own chance of this, stated with the estimate: 85%; the middle value does not contradict the limit.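

Compound 2 and compound 3 both return only limits in this assay, so no step can be read between them: the limit of > 32000 nM in this assay, at which 3 of the 3 values shown sit.

The compounds shown leave open whether bromo in place of ethynyl changes inhibition at all.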